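A few compounds are considered here, and "the series" means these few. Any claim that something is new, unique, unknown or untested is made for them only; others in the source may bear on it.

Of the compounds shown here, three have been measured in a functional assay on MCF7 cells (Homo sapiens) for cytotoxicity, read by MTT assay, with a stated time of 72 h; on this read-out lower numbers stand for stronger inhibition of growth and higher numbers for weaker inhibition of growth. Compound 1 `COc1ccc(OC(=O)Nc2ccc([Se]C#N)cc2)cc1` carries a selenocyanate on one aromatic ring and a methoxy on the other, and in this assay compound 1 gives 22400 nM. Compound 2 `CCCCOC(=O)Nc1ccc([Se][Se]c2ccc(NC(=O)OCCCC)cc2)cc1`, in which two aryl units are joined through a diselenide, gives 17300 nM in this assay. Compound 3 `O=C(Nc1ccc([Se][Se]c2ccc(NC(=O)OCc3ccc([N+](=O)[O-])cc3)cc2)cc1)OCc1ccc([N+](=O)[O-])cc1`, built the same way but with nitrobenzyl carbamates at both ends, gives 20600 nM in this assay. Compound 1 stands level with the other two: its gap to compound 3 and its gap to compound 2 both lie within the usual scatter of repeated measurements, so none of the three can be called stronger or weaker than another.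

Compound 4 `N#C[Se]c1ccc(NC(=O)Oc2ccccc2)cc1` has not yet been measured. It differs from compound 1 in one place: hydrogen in place of methoxy on an aromatic carbon. Among the measured compounds shown here, no pair of measured compounds differing in a single place is available, so the expectation rests only on the change itself and on the level of the three measured numbers. A move of this kind is expected to stay within the scatter, so the step of a 1.0-fold lower number from compound 1 to compound 4 (0.01 log units; within the scatter) is estimated as essentially flat. Compound 4 is therefore expected to give about 22000 nM in this assay, most likely between 9000 nM and 50000 nM.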

Compound 4, concentration for 50% growth inhibition: 4000 nM
The estimate for compound 4 lay 5.5-fold (0.74 log units) above the measured number; the measured number lies below the stated range.
By their numbers in this assay, from the lowest: compound 4; then compounds 2, 3 and 1 (each within the scatter of the next).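

Putting hydrogen in place of methoxy on this aromatic carbon, para to a large group, gives a 5.6-fold lower number from compound 1 to compound 4 (0.75 log units; beyond the scatter) in this assay and so takes the number beyond the usual scatter. Among the compounds shown here, the three earlier compounds could not show this, since their numbers lie level with one another and no two of them differ in only one place; this pair is the first evidence that what sits at this position matters to growth inhibition, with the unsubstituted ring giving the stronger inhibition of the two. Nothing available here accounts for the size or the direction of this step.

On these data alone, only methoxy and hydrogen have been compared at this position, so it remains open whether any group there gives a number like that of compound 1 or whether something particular to methoxy is at work, a question that a methyl, a fluorine, a hydroxyl or an amine at the same place could help to answer. As far as these compounds go, it is also open whether the same change would have a similar effect on another core, such as a diselenide carrying the same aryl carbamate.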